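The source may hold more compounds than are shown below. What is called first, only, known or untested is meant among the compounds shown, and "the series" means these compounds.

Measured in a toxicity assay on HT-29 cells (Homo sapiens) for cytotoxicity (a higher number here means that more compound is tolerated, a lower number that less compound is tolerated), so far:
- compound 1 `CCCn1nc(C(=O)N[C@H]2COc3ccccc3N(C)C2=S)nc1Cc1ccccc1` gives > 100000 nM as a limit
- compound 2 `COCCn1nc(C(=O)N[C@H]2COc3ccccc3N(C)C2=S)nc1Cc1ccccc1` gives > 100000 nM as a limit
- compound 3 `CN1C(=S)[C@@H](NC(=O)c2nc(Cc3ccccc3)n(C3CCCCC3)n2)COc2ccccc21` gives > 100000 nM as a limit

Compound 3 stands at > 100000 nM (a limit, not a number). Among the measured compounds shown here, no number is available for any compound so far (the limit of > 100000 nM in this assay, at which 3 of the 3 values shown sit).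

Compound 4 `CN1C(=S)[C@@H](NC(=O)c2nc(Cc3ccccc3)n(CC3CCOCC3)n2)COc2ccccc21` carries (oxan-4-yl)methyl in place of cyclohexyl on an aromatic nitrogen.

The measured changes on that nitrogen are (a step that the two limits leave unreadable from compound 1 to compound 3) and (a step that the two limits leave unreadable from compound 2 to compound 3). The chain change (a step that the two limits leave unreadable from compound 1 to compound 2) bears on it less directly. None of these gives a size to carry over. Compound 2, with 2-methoxyethyl on that nitrogen, gives > 100000 nM as a limit too.

On this basis, no step beyond the usual scatter is expected in this assay and no direction can be expected. The expected step is (a number no higher from compound 3 to compound 4 (the limit leaves the size open)). Compound 4 is estimated at 100000 nM (expected range 40000 nM to 200000 nM).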

Compound 4, half-maximal cytotoxic concentration: > 100000 nM
Compound 4 gave a limit, no number (the forecaster's own chance of this, stated with the estimate: 90%); the middle value lies on the limit itself.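

Compound 4, like compound 1, compound 2 and compound 3, gives only a limit in this assay, so no new step can be read: the limit of > 100000 nM in this assay, at which 4 of the 4 values shown sit.

In this assay, the compounds shown leave open whether the group on the aromatic nitrogen affects the half-maximal cytotoxic concentration at all.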